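Swapping the amine on the acyl arm of compound 3

The compounds below may be only part of what the source reports. "The series", "measured", "known", "first", "only" and "open" are said of these compounds alone.

Measured so far:
compound 1, `O=C(c1ccccc1)N1N=C(c2cc3ccccc3oc2=O)CC1c1ccccc1`, 12700 nM
compound 2, `Cc1ccc(S(=O)(=O)N2N=C(c3cc4ccccc4oc3=O)CC2c2ccccc2)cc1`, 50200 nM
compound 3, `O=C(CNC1CCCCC1)N1N=C(c2cc3ccccc3oc2=O)CC1c1ccccc1`, 26400 nM

All three were tested in a functional assay on MGC-803 cells (Homo sapiens) for cytotoxicity, read by MTT assay, with a stated time of 48 h; on this read-out higher numbers stand for weaker inhibition and lower numbers for stronger inhibition. Compound 3 stands second highest of the three numbers: its nearest neighbour is compound 2, and the step of a 1.9-fold lower number from compound 2 to compound 3 (0.28 log units; within the scatter) lies within the scatter, while the step of a 2.1-fold higher number from compound 1 to compound 3 (0.32 log units; beyond the scatter) lies beyond it. The remaining pair, a 4.0-fold higher number from compound 1 to compound 2 (0.60 log units; beyond the scatter), is the largest step among the three, and all of these steps concern the group on the amine nitrogen in the ring of the shared core.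

Compound 4, `NC(=O)C1CCN(CC(=O)N2N=C(c3cc4ccccc4oc3=O)CC2c2ccccc2)CC1`, differs from compound 3 by 4-carbamoylpiperidin-1-yl in place of cyclohexylamino on a saturated chain carbon bound to a carbonyl carbon. Within the data shown here, no measured step alters this part of the molecule; the steps involving compound 3 change the whole group on the ring nitrogen, and even those were modest. A change further out along the acyl arm is therefore expected to move the number little, if at all, in this assay. The estimate for compound 4 is 30000 nM, between 12000 nM and 80000 nM, corresponding to an expected step of a 1.1-fold higher number from compound 3 to compound 4 (0.06 log units; within the scatter).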

Compound 4, half-maximal inhibitory concentration: 21500 nM
The estimate for compound 4 lay 1.4-fold (0.14 log units) above the measured number; the range from low to high includes it.
By their numbers in this assay, from the lowest: compounds 1, 4, 3 and 2 (each within the scatter of the next, the first and the last beyond it).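

In this assay, 4-carbamoylpiperidin-1-yl in place of cyclohexylamino on a saturated chain carbon bound to a carbonyl carbon gives a step within the scatter (a 1.2-fold lower number from compound 3 to compound 4 (0.09 log units; within the scatter)), so this first change made at this position leaves the read-out unresolved from that of compound 3, even though the entering group is larger and has a hetero atom in its ring. Set against the benzoyl compound, (4-carbamoylpiperidin-1-yl)methyl in place of phenyl on a carbonyl carbon also stays within the scatter (a 1.7-fold higher number from compound 1 to compound 4 (0.23 log units; within the scatter)), whereas (cyclohexylamino)methyl in the same place lay just beyond it (a 2.1-fold higher number from compound 1 to compound 3 (0.32 log units; beyond the scatter)). Nothing available here offers an explanation for these results.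

The compounds shown leave open whether a carboxylic acid in place of the carbamoyl, or a morpholine in place of the piperidine, would also leave the number unresolved. They also leave open what a longer chain carrying the same amine would do.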